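The compounds below may be only part of what the source reports. "The series", "measured", "known", "first", "only" and "open" are said of these compounds alone.

Working notes on the series.

Three compounds share one core and differ only in the group on an amine nitrogen whose other neighbour is a double-bonded ring carbon. Compound 1 `CCOC(=O)C1=C(N/C=N/c2nnc(S(N)(=O)=O)s2)Nc2[nH]nc(C)c2C1c1ccc(N(C)C)cc1` gives 26300 nM in a functional assay on HeLa cells (Homo sapiens) for inhibition, read by MTT assay, with a stated time of 48 h; a higher number here means a weaker inhibitor, a lower number a stronger inhibitor. Compound 2 `CCOC(=O)C1=C(N/N=C(\C#N)C(N)=O)Nc2[nH]nc(C)c2C1c1ccc(N(C)C)cc1` gives 47300 nM, and compound 3 `CCOC(=O)C1=C(NN=C(C#N)C#N)Nc2[nH]nc(C)c2C1c1ccc(N(C)C)cc1` gives 15200 nM. Compound 1 stands second highest of the three; its nearest neighbour is compound 3, with a 1.7-fold lower number from compound 1 to compound 3 (0.24 log units; within the scatter), and the furthest is compound 2, with a 1.8-fold higher number from compound 1 to compound 2 (0.25 log units; within the scatter). Between the two acyclic groups the step is a 3.1-fold lower number from compound 2 to compound 3 (0.49 log units; beyond the scatter), the only one of the three that goes beyond the scatter.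

Compound 4 `CCOC(=O)C1=C(N/N=C(/C(=O)Br)c2ccc(Cl)cc2)Nc2[nH]nc(C)c2C1c1ccc(N(C)C)cc1` is not yet measured. It changes the same position: a group of 12 heavy atoms (8 carbon, 1 nitrogen, 1 oxygen, 1 chlorine, 1 bromine; one six-membered aromatic ring of carbon only) in place of a group of 11 heavy atoms (3 carbon, 4 nitrogen, 2 oxygen, 2 sulfur; one five-membered aromatic ring with 3 hetero atoms), on an amine nitrogen

All three measured steps bear on this change, since each swaps the group on that same amine nitrogen, and none moves the number by much: two within the scatter and one modest. The group entering in compound 4 is of a different kind from any measured one, so the direction is not fixed by the data. An expected step of a 1.2-fold lower number from compound 1 to compound 4 (0.08 log units; within the scatter) is therefore set close to no change, with a wide range. For compound 4 the estimate in this assay is 22000 nM, between 7000 nM and 70000 nM.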

Compound 4, half-maximal inhibitory concentration: 49300 nM
The estimate for compound 4 lay 2.2-fold (0.35 log units) below the measured number; low and high end bracket the measured number.
By their numbers in this assay, from the lowest: compounds 3, 1, 2 and 4 (each within the scatter of the next, the first and the last beyond it).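

In this assay, the group of 12 heavy atoms, with its six-membered aromatic ring of carbon only and 0 hydrogen-bond donors, stays within the scatter of the group it replaces on this amine nitrogen (a 1.9-fold higher number from compound 1 to compound 4 (0.27 log units; within the scatter)) and of the group in compound 2 (a 1.0-fold higher number from compound 2 to compound 4 (0.02 log units; within the scatter)). Within the data shown here, a group of a different kind from the earlier ones, carrying a chlorine and a bromine, therefore gives a number that cannot be told apart from those of compound 1 and compound 2, and the only step beyond the scatter that it adds is the modest one from the group of 6 heavy atoms (a 3.2-fold higher number from compound 3 to compound 4 (0.51 log units; beyond the scatter)). Compound 3 now stands apart from both compound 2 and compound 4 but not from compound 1, so the four groups separate only slightly, and nothing at hand bears on what lies behind these numbers.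

The compounds shown do not separate the contribution of the chlorine from that of the bromine-bearing carbonyl, as no pair differs in only one of them. On these data alone, how this amine nitrogen responds to a carboxylic acid, a basic amine or a plain alkyl chain remains open.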